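The source may hold more compounds than are shown below. What is called first, only, known or untested is meant among the compounds shown, and "the series" means these compounds.

Measured so far in a functional assay on HCT-116 cells (Homo sapiens) for inhibition, read by colorimetric assay, with a stated time of 3 days; on this read-out higher numbers stand for weaker inhibition and lower numbers for stronger inhibition:
compound 1 `COc1ccc(-c2cnc(NC(=O)CCCCCCNC(=O)C(O)(O)C(F)(F)F)s2)cc1` gives 930 nM
compound 2 `O=C(CCCCCCNC(=O)C(O)(O)C(F)(F)F)Nc1ccccc1Br` gives 14500 nM
compound 3 `O=C(CCCCCCNC(=O)C(O)(O)C(F)(F)F)Nc1ccncc1` gives 6670 nM

Compound 3 at 6670 nM holds the second highest of the three numbers, lying under compound 2 and over compound 1. The next compound is compound 4 `O=C(CCCCCCNC(=O)C(O)(O)C(F)(F)F)Nc1nc2ccccc2o1` with the change 1,3-benzoxazol-2-yl in place of pyridin-4-yl on an amide-type nitrogen in which 1,3-benzoxazol-2-yl stands in place of pyridin-4-yl on an amide-type nitrogen.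

Among the measured compounds shown here, only one measured step bears on this place. That step a 2.2-fold lower number from compound 2 to compound 3 (0.34 log units; beyond the scatter) is modest and beyond the scatter, and it has pyridin-4-yl in place of 2-bromophenyl. For the measured compounds named here, no measured compound carries 1,3-benzoxazol-2-yl, so the size of the step rests on thin evidence. Compound 1 at 930 nM has a different group on the same nitrogen and shows a clearly lower number than compound 3. Compound 2 at 14500 nM marks the high end of the three numbers.

Going by the values given here, a modest step is therefore expected in this assay toward a lower number, of about the size of the one measured step. The expected move is a 2.2-fold lower number from compound 3 to compound 4 (0.35 log units; beyond the scatter) as a working estimate. For compound 4 the estimated value is 3000 nM with an expected range from 900 nM to 9000 nM in this series.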

Compound 4, half-maximal inhibitory concentration: 3450 nM
Compound 4: middle estimate off by 1.2-fold (0.06 log units), on the low side; the measured number falls inside the stated range.
By their numbers in this assay, from the lowest: compound 1; then compounds 4 and 3 (each within the scatter of the next); then compound 2.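

In this assay, 1,3-benzoxazol-2-yl in place of pyridin-4-yl on the amide-type nitrogen gives a 1.9-fold lower number from compound 3 to compound 4 (0.29 log units; within the scatter), so a group with a five-membered and a six-membered aromatic ring cannot be told apart here from the single six-membered ring of pyridin-4-yl. Set against 2-bromophenyl, the same group gives a 4.2-fold lower number from compound 2 to compound 4 (0.62 log units; beyond the scatter), and together with a 2.2-fold lower number from compound 2 to compound 3 (0.34 log units; beyond the scatter) this places both groups with ring hetero atoms on the same side of compound 2 in this small set. No independent evidence accounts for these differences.

On these data alone, compound 1 gives 930 nM with its own larger group on the same nitrogen, and it remains open which part of that group goes with this number. Also open, as far as these compounds go, is how the number responds to an amine or a carboxylic acid on the group at this nitrogen, and to a longer chain in place of the one in the shared core.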